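From piperidin-3-yl to piperidin-4-yl on a carbonyl carbon

The source may report more compounds than this note shows. Statements on the series, on what has been measured and on what is new or still open speak of the compounds shown alone.

In a functional assay on a cell-free system (Platelet, plasma, Homo sapiens) for inhibition (a lower number here means a stronger inhibitor, a higher number a weaker inhibitor), compound 1 `CCCCCCOc1cccc(NC(=O)C2CCCNC2)c1` gives 113000 nM, and compound 2 `O=C(Nc1cccc(OCc2ccccc2)c1)C1CCCNC1` gives 128000 nM. Among the measured compounds shown here, these two numbers cannot be ranked, since the only measured step is a 1.1-fold higher number from compound 1 to compound 2 (0.05 log units; within the scatter). Compound 2 therefore stands level with compound 1, and the exchange of pentyl for phenyl on a saturated chain carbon bound to an oxygen on an aromatic ring leaves the reading where it was.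

Compound 3 `O=C(Nc1cccc(OCc2ccccc2)c1)C1CCNCC1` has the same atoms as compound 2, joined differently: piperidin-4-yl in place of piperidin-3-yl on a carbonyl carbon. In words, piperidin-4-yl takes the place of piperidin-3-yl on a carbonyl carbon. The measured step bears on this only indirectly. It changes another part of the molecule. For the measured compounds named here, no measured compound carries piperidin-4-yl, so the data offer no direction for the change. In this assay the expected result is therefore no shift beyond the scatter. The expected step is a 1.1-fold lower number from compound 2 to compound 3 (0.03 log units; within the scatter). For compound 3 the estimate is 120000 nM, with an expected range from 40000 nM to 350000 nM.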

Compound 3, half-maximal inhibitory concentration: 229000 nM
Beside the measured number, compound 3's estimate is 1.9-fold (0.28 log units) below it; the range from low to high includes it.
By their numbers in this assay, from the lowest: compounds 1, 2 and 3 (each within the scatter of the next, the first and the last beyond it).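

In this assay, piperidin-4-yl in place of piperidin-3-yl on a carbonyl carbon gives a 1.8-fold higher number from compound 2 to compound 3 (0.25 log units; within the scatter), so the two attachments of the piperidine cannot be told apart here on this evidence. Among the compounds shown here, the earlier step concerned only the group on the oxygen, and this is the first reading at the carbonyl carbon whose other neighbour is the amide-type nitrogen: with the phenyl-bearing side of compound 2 held fixed, this exchange of one ring attachment for the other does not separate compound 3 from compound 2. There is no independent evidence on what lies behind either reading.

Whether piperidin-4-yl would read the same alongside the pentyl-bearing side of compound 1 remains open, since that pairing is not among the compounds shown. Also open, as far as these compounds go, is what a different group on the carbonyl carbon would give, such as a pyrrolidin-3-yl ring, piperidin-2-yl or an open-chain amine, and whether any of these would produce a step beyond the scatter.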